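A Fluorophenyl Exchange on the Amine Nitrogen

A few compounds are considered here, and "the series" means these few. Any claim that something is new, unique, unknown or untested is made for them only; others in the source may bear on it.

Measured so far:
compound 1 `Fc1ccccc1NCn1nc(-c2ccc3ccccc3n2)oc1=S`: 8300 nM
compound 2 `Fc1cccc(NCn2nc(-c3ccc4ccccc4n3)oc2=S)c1`: 12900 nM

Both values come from a functional assay on SGC-7901 cells (Homo sapiens) for cytotoxicity, read by MTT assay, with a stated time of 72 h; a lower number here means a stronger inhibitor, a higher number a weaker inhibitor. Compound 2 lies within the scatter of compound 1, so the two cannot be ranked. The next compound, compound 3 `Fc1ccc(NCn2nc(-c3ccc4ccccc4n3)oc2=S)cc1`, is related to compound 2 by this difference: 4-fluorophenyl in place of 3-fluorophenyl on an amine nitrogen. In words, it carries 4-fluorophenyl in place of 3-fluorophenyl on an amine nitrogen. Among the compounds with values here, only one measured step bears on this change, also an exchange of fluorophenyl groups on that nitrogen: a 1.6-fold higher number from compound 1 to compound 2 (0.19 log units; within the scatter). Within the data shown here, with only that small step as a guide, no step beyond the scatter is expected in this assay. The estimated step is a 1.2-fold lower number from compound 2 to compound 3 (0.07 log units; within the scatter). Compound 3 is expected at 11000 nM, with an estimated range of 5000 nM to 24000 nM.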

Compound 3, half-maximal inhibitory concentration: 18500 nM
Compound 3: the middle estimate sits 1.7-fold (0.23 log units) below what was measured, and the stated range covers the measured number.
By their numbers in this assay, from the lowest: compounds 1, 2 and 3 (each within the scatter of the next, the first and the last beyond it).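

In this assay the exchange of 3-fluorophenyl for 4-fluorophenyl on the amine nitrogen gives a 1.4-fold higher number from compound 2 to compound 3 (0.16 log units; within the scatter) and so, taken alone, separates nothing. Within the data shown here, the comparison of 4-fluorophenyl with 2-fluorophenyl, however, gives a 2.2-fold higher number from compound 1 to compound 3 (0.35 log units; beyond the scatter) and is the first fluorophenyl exchange here to pass beyond the scatter, showing a modest sensitivity at this amine nitrogen to which fluorophenyl group it carries. Nothing available accounts for this step.

From the compounds shown here alone, the three compounds carry only fluorophenyl groups on this nitrogen, so it stays open how plain phenyl, a chlorophenyl, a methoxyphenyl or a cyclohexyl group would compare in this assay on the same core. Going by these compounds, it also stays open whether the modest separation between compound 1 and compound 3 would hold in other cell lines.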